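A few compounds are considered here, and "the series" means these few. Any claim that something is new, unique, unknown or untested is made for them only; others in the source may bear on it.

Measured so far: compound 1 `CCCCn1cc(C(=O)O)c(=O)c2c(O)c(Cc3cccc(Cl)c3F)ccc21` gives 20000 nM in an ADME assay on C8166 cells (Homo sapiens) for cytotoxicity, read by MTT assay; on this read-out higher numbers stand for lower toxicity in this test and lower numbers for higher toxicity in this test; compound 2 `CC(C)Cn1cc(C(=O)O)c(=O)c2c(O)c(Cc3cccc(Cl)c3F)ccc21` gives 19500 nM.

Compound 1 holds the higher of the two numbers, yet its nearest neighbour is compound 2, and the step of a 1.0-fold lower number from compound 1 to compound 2 (0.01 log units; within the scatter) stays within the scatter. Compound 3 `O=C(O)c1cn(C2CCCCC2)c2ccc(Cc3cccc(Cl)c3F)c(O)c2c1=O` differs from compound 1 by cyclohexyl in place of butyl on an aromatic nitrogen. Among the compounds with values here, the only comparable step is the chain change at the same nitrogen, a 1.0-fold lower number from compound 1 to compound 2 (0.01 log units; within the scatter), which gave no movement beyond the scatter, so no movement beyond the scatter is expected here either: the expected step is no change at the digits printed from compound 1 to compound 3 (within the scatter). Compound 3 is therefore estimated at 20000 nM, within 10000 nM to 40000 nM.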

Compound 3, half-maximal cytotoxic concentration: 17400 nM
Beside the measured number, compound 3's estimate is 1.1-fold (0.06 log units) above it, and the stated range covers the measured number.
By their numbers in this assay, from the lowest: compounds 3, 2 and 1 (each within the scatter of the next).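

Replacing an open chain with a ring on the aromatic nitrogen gives a 1.1-fold lower number from compound 1 to compound 3 (0.06 log units; within the scatter) in this assay, and replacing isobutyl with cyclohexyl gives a 1.1-fold lower number from compound 2 to compound 3 (0.05 log units; within the scatter). Among the compounds shown, this position therefore accepts one six-membered non-aromatic ring of carbon only as well as the branched and unbranched chains, with all three numbers within the scatter of one another. No available evidence bears on this result. The compounds shown leave open whether a chain ending in an amine or a carboxylic acid, or a phenyl ring, on this nitrogen would also stay within the scatter.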